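Hydrogen for methoxy: metabolic stability of a quinolone pair

The source may report more compounds than this note shows. Statements on the series, on what has been measured and on what is new or still open speak of the compounds shown alone.

Of the compounds shown here, three have been read in an ADME assay on cells (Hepatocyte, Rattus norvegicus) for metabolic stability, read by LC-MS, using NADPH, with a stated time of 45 min, tested at 3 uM; on this read-out higher numbers stand for fast clearance and lower numbers for slow clearance. Compound 1 `Cc1c(-c2ccnc(-c3ccc(OC(F)(F)F)cc3)c2)[nH]c2ccccc2c1=O` gives 2.5 uL/min, compound 2 `COc1ccc2c(=O)c(C)c(-c3cncc(-c4ccc(OC(F)(F)F)cc4)c3)[nH]c2c1` gives 1.2 uL/min, and compound 3 `COc1ccc2c(=O)c(C)c(-c3cncc(-c4ccc(Cl)c(Cl)c4)c3)[nH]c2c1` gives 4.9 uL/min. Compound 3 holds the highest of the three numbers; its gap to compound 1 sits within the scatter, while its gap to compound 2 lies beyond it. No pair among these three differs in one place only, so no single step has been measured. Compound 4 `Cc1c(-c2cncc(-c3ccc(Cl)c(Cl)c3)c2)[nH]c2ccccc2c1=O` is the next candidate for this assay. hydrogen in place of methoxy on an aromatic carbon The step from compound 3 to compound 4 is expected to be small, likely none beyond the scatter, perhaps a slight move toward faster clearance, giving a 1.1-fold higher number from compound 3 to compound 4 (0.05 log units; within the scatter). Compound 4 is therefore estimated at 5.5 uL/min, with a range from 2.5 uL/min to 12 uL/min.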

Compound 4, intrinsic clearance in a liver preparation (reported as CLH), per the amount of preparation that the assay uses: 9.9 uL/min
Compound 4: middle estimate off by 1.8-fold (0.26 log units), on the low side, and the stated range covers the measured number.
By their numbers in this assay, from the lowest: compound 2; then compounds 1 and 3 (each within the scatter of the next); then compound 4.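

In this assay, among these compounds, hydrogen in place of methoxy gives a 2.0-fold higher number from compound 3 to compound 4 (0.31 log units; beyond the scatter) and provides the first reading of a single change. On this aromatic carbon, then, the methoxy compound carries the lower clearance number, though this rests on one pair only. Nothing at hand accounts for the step.

On these data alone, whether the step carries over to compounds bearing the trifluoromethoxy group remains open. So does the reading for fluorine, ethoxy or an amine on this same carbon.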